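Amino in Place of Bromo: An Expected Shift

A few compounds are considered here, and "the series" means these few. Any claim that something is new, unique, unknown or untested is made for them only; others in the source may bear on it.

Of the compounds shown here, three that share one core have been measured in an assay on HEK293 cells for binding affinity to 5-hydroxytryptamine receptor 7 (Homo sapiens), read by radioligand binding, tested at 1 uM; a lower number here means less inhibition, a higher number more inhibition at the concentration tested (going by the name of the read-out). Compound 1 `Brc1ccc2ccn(CCN3CCN4CCCCC4C3)c2c1` gives 78%. Compound 2 `CN1CCCN(CCn2ccc3ccc(Br)cc32)CC1` gives 93%, the highest of the three numbers. Compound 3 `Brc1ccc2ccn(CCN3CCC4CCCCN4CC3)c2c1` gives 71%. Compound 2 stands above its nearest neighbour, compound 1, by a margin beyond the usual scatter, and further still above compound 3, again beyond the scatter.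

Compound 4 `CN1CCCN(CCn2ccc3ccc(N)cc32)CC1` has not yet been measured. It differs from compound 2 in a single place: amino in place of bromo on an aromatic carbon. Within the data shown here, no measured pair in this set shows the same change, so nothing here tells directly how such a swap plays out. The expectation is a decrease in this assay beyond the scatter, of moderate size, as the step of a number 23 percentage points lower from compound 2 to compound 4 (beyond the scatter). Compound 4 is therefore estimated to give 70%, with a range expected to run from 45% to 90%.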

Compound 4, a percentage reported as inhibition, at one concentration (the size of the read-out at that concentration, not a potency): 0%
Beside the measured number, compound 4's estimate is 70 percentage points above it; the measured number lies below the stated range.
By their numbers in this assay, from the lowest: compound 4; then compounds 3 and 1 (each within the scatter of the next); then compound 2.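

In this assay, among these compounds, amino in place of bromo on this aromatic carbon gives a number 93 percentage points lower from compound 2 to compound 4 (beyond the scatter), the first step in the set that speaks to this position, as the earlier compounds all carry bromo there. The position is therefore far from indifferent to what it holds: exchanging one heavy atom for another, with a hydrogen-bond donor and a hydrogen-bond acceptor entering, is enough for a step of this size. Nothing available here accounts for why this change acts as it does.

From the compounds shown here alone, whether the fall is tied to amino itself or would follow any loss of bromo stays open, and chloro, methyl or methoxy on the same carbon would help to separate the two. Also open, going by these compounds, is whether the same swap would act alike on the cores of compound 1 and compound 3.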